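The source may hold more compounds than are shown below. What is called first, only, known or untested is meant among the compounds shown, and "the series" means these compounds.

Compound 1 `CCCC(=O)N1N=C(c2cc(OC)ccc2N)SC1(C)C` and compound 2 `COc1ccc(N)c(C2=NN(C(=O)C3CC3)C(C)(C)S2)c1` share one core and differ only in the group on the carbonyl carbon. In an assay on isolated protein for inhibition of Nitric oxide synthase, inducible (Homo sapiens), read by scintillation counting, with a stated time of 30 min (a higher number here means a weaker inhibitor, a lower number a stronger inhibitor), compound 1 gives 29600 nM. In this assay compound 2 gives 41000 nM. The step of a 1.4-fold higher number from compound 1 to compound 2 (0.14 log units; within the scatter) is within the scatter, so compound 2 and compound 1 stand at the same level as far as these two numbers can tell, and the whole pair sits in the weak range.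

Compound 3 `COc1ccc(N)c(C2=NN(C(=O)C3CCCCC3)C(C)(C)S2)c1` takes the next step of the same kind: cyclohexyl in place of cyclopropyl on a carbonyl carbon. Among the compounds with values here, the only measured step that bears on this is a 1.4-fold higher number from compound 1 to compound 2 (0.14 log units; within the scatter), and it shows that trading one small carbon group for another on this carbonyl carbon left the number where it was. The same is therefore expected here: no change beyond the scatter, so the step of a 1.0-fold lower number from compound 2 to compound 3 (0.01 log units; within the scatter) is the estimate. Compound 3 is expected to give 40000 nM, within the range 15000 nM to 110000 nM.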

Compound 3, half-maximal inhibitory concentration: 21900 nM
Compound 3: middle estimate off by 1.8-fold (0.26 log units), on the high side; the measured number falls inside the stated range.
By their numbers in this assay, from the lowest: compounds 3, 1 and 2 (each within the scatter of the next).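

Cyclohexyl, with 6 heavy atoms, replaces cyclopropyl, with 3, a larger change in size than the earlier swap, yet the result is a 1.9-fold lower number from compound 2 to compound 3 (0.27 log units; within the scatter) and no clear shift. Set against the open chain, the same ring gives a 1.4-fold lower number from compound 1 to compound 3 (0.13 log units; within the scatter) and so leaves propyl, cyclopropyl and cyclohexyl on this carbonyl carbon at one level in this assay as far as these numbers can tell. Nothing available explains why these three groups read alike.

Going by these compounds, whether a group carrying an amine or a carboxylic acid on this carbonyl carbon would move the number beyond the scatter remains open. So does the question of whether a longer chain or a phenyl ring there would do so.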